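The source may hold more compounds than are shown below. What is called first, only, known or untested is meant among the compounds shown, and "the series" means these compounds.

Working notes on the series.

Of the compounds shown here, two have numbers so far. Among the compounds with values here, compound 1 `CC1=C(C(=O)OC(C(F)(F)F)C(F)(F)F)C(c2ccsc2)NC(=O)N1` and compound 2 `CC1=C(C(=O)OCC(F)(F)F)C(c2ccco2)NC(=O)N1` differ in two places at once, so no single step between them is written out; only their two values can be set side by side. In an assay on HeLa cells for displacement of a labelled ligand from adenosine receptor A3 (Homo sapiens), read by radioligand binding, with a stated time of 180 min, tested at 1 uM (a lower number here means less inhibition, a higher number more inhibition at the concentration tested (going by the name of the read-out)), compound 1 gives 8% and compound 2 gives 1%. Compound 2 carries the lowest of the two numbers, and the nearest number, that of compound 1, lies within the scatter of it, so no order between the two can be read from these values.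

Compound 3 `CC1=C(C(=O)OC(C(F)(F)F)C(F)(F)F)C(c2ccco2)NC(=O)N1` is the next compound to be measured. Against compound 2 the change is trifluoromethyl in place of hydrogen on a saturated chain carbon bound to an oxygen next to a carbonyl group and a saturated chain carbon. Nothing in the measured pair isolates this change, since compound 1 differs from compound 2 in a second place as well. Given that both measured values sit close together and low, a step from compound 2 to compound 3 of a number 4 percentage points higher from compound 2 to compound 3 (within the scatter) is expected, which is within the scatter. Compound 3 is estimated at 5%, with a range from -5% to 15%.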

Compound 3, a percentage reported as inhibition, at one concentration (the size of the read-out at that concentration, not a potency): 2%
Beside the measured number, compound 3's estimate is 3 percentage points above it; the range from low to high includes it.
By their numbers in this assay, from the lowest: compounds 2, 3 and 1 (each within the scatter of the next).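

In this assay, within the data shown here, trifluoromethyl in place of hydrogen on a saturated chain carbon bound to an oxygen next to a carbonyl group and a saturated chain carbon gives a number 1 percentage points higher from compound 2 to compound 3 (within the scatter) and so, now seen on its own for the first time, leaves no readable mark on the number. Furan-2-yl in place of thiophen-3-yl on a saturated ring carbon, with the rest of the structure unchanged, gives a number 6 percentage points lower from compound 1 to compound 3 (within the scatter) and so does not separate the two ring groups at the concentration tested. No measurement to hand bears on why these numbers sit where they do.

Still open, going by these compounds, is whether any other group at these two places would move the number beyond the scatter, such as an amine, a carboxylic acid or a longer chain on the saturated chain carbon, or a phenyl ring on the saturated ring carbon. Also open, on these data alone, is whether the same two changes would stay as silent in a compound whose number lies well above those of compound 1, compound 2 and compound 3.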